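The source may hold more compounds than are shown below. What is called first, only, known or untested is meant among the compounds shown, and "the series" means these compounds.

Values measured in a physicochemical assay for solubility, read by HPLC, in phosphate buffer, measured as kinetic solubility, at pH 7.4; on this read-out higher numbers stand for higher solubility and lower numbers for lower solubility:
- compound 1 `CCC(=O)c1cc(-c2ccc(Cl)cc2)n(-c2ccc(S(N)(=O)=O)cc2)c1`: 19500 nM
- compound 2 `CCC(=O)c1cc(-c2ccc(Cl)cc2)n(-c2ccc(S(=O)(=O)N(C)C)cc2)c1C`: 1200 nM
- compound 3 `CCC(=O)c1cc(-c2ccccc2)n(-c2ccc(S(N)(=O)=O)cc2)c1C`: 14100 nM

Compound 3, at 14100 nM, lies within the usual scatter of compound 1, at 19500 nM, and well above compound 2, at 1200 nM. Among these three numbers, it therefore belongs with the high pair rather than with the low one.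

The next compound to be read in this assay is compound 4 `CCC(=O)c1cc(-c2ccc(OC)cc2)n(-c2ccc(S(N)(=O)=O)cc2)c1C`. It departs from compound 3 in a single place: methoxy in place of hydrogen on an aromatic carbon. This puts methoxy in place of hydrogen on an aromatic carbon, para to a large group, so that phenyl becomes 4-methoxyphenyl.

Among the compounds with values here, no two measured compounds differ in only one place, so the data offer no direct precedent for this change. Compound 1, at 19500 nM, differs from compound 3 in more than one place, yet the two values remain within the scatter of each other, so a large step is not expected here. A small downward step is expected, most likely one that stays within the scatter. The estimated step is a 1.6-fold lower number from compound 3 to compound 4 (0.19 log units; within the scatter). For compound 4 the expected value is 9000 nM, with an estimated range from 3000 nM to 20000 nM.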

Compound 4, solubility: 12800 nM
Compound 4: the middle estimate sits 1.4-fold (0.15 log units) below what was measured; the range from low to high includes it.
By their numbers in this assay, from the lowest: compound 2; then compounds 4, 3 and 1 (each within the scatter of the next).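

In this assay, within the data shown here, this pair gives the first direct reading of a single change, a 1.1-fold lower number from compound 3 to compound 4 (0.04 log units; within the scatter), so methoxy in place of hydrogen on an aromatic carbon, para to a large group, cannot be told apart from the usual scatter of repeated measurements. Among these compounds, until now no two compounds differed in only one place, so this position had no reading of its own; phenyl and 4-methoxyphenyl can now be set side by side on an otherwise identical structure, and on this read-out the two compounds stand level. No measurement at hand bears on why the added methoxy leaves the two numbers within the scatter of each other.

This single pair leaves open how other groups would read at the same place, such as an amine, a carboxylic acid, or a longer chain like ethoxy or propoxy in place of methoxy. It also leaves open whether the same exchange of hydrogen for methoxy would give a step of similar size on any other compound in the series, since it has so far been read on only one background.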